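The source may hold more compounds than are shown below. What is called first, only, known or untested is meant among the compounds shown, and "the series" means these compounds.

Compound 1 `NC1=NC2(CCSCC2)N(OCCCOc2cccc(Cl)c2)C(N)=N1`: 90 nM
Compound 2 `NC1=NC2(CCSCC2)N(OCCCOc2cccc(Cl)c2Cl)C(N)=N1`: 50 nM

In a functional assay on HepG2 cells (Homo sapiens) for antiproliferative activity, read by MTT assay, with a stated time of 72 h (a lower number here means a stronger inhibitor, a higher number a weaker inhibitor), compound 2 has the lower of the two numbers, but a 1.8-fold lower number from compound 1 to compound 2 (0.26 log units; within the scatter) lies within the scatter, so compound 1 and compound 2 are not separable on these data. Compound 3 `NC1=NC2(CCSCC2)N(OCCCOc2ccccc2Cl)C(N)=N1` differs from compound 2 by hydrogen in place of chloro on an aromatic carbon. Within the data shown here, the single measured step, a 1.8-fold lower number from compound 1 to compound 2 (0.26 log units; within the scatter), concerns the chloro that remains in compound 3, not the one that leaves; no measured step covers the leaving chloro. Compound 3 is expected to stay close to compound 2, with a 1.4-fold higher number from compound 2 to compound 3 (0.15 log units; within the scatter) expected within the scatter. Compound 3 is estimated at 70 nM, between 30 nM and 200 nM.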

Compound 3, half-maximal inhibitory concentration: 80 nM
Beside the measured number, compound 3's estimate is 1.1-fold (0.06 log units) below it, and the stated range covers the measured number.
By their numbers in this assay, from the lowest: compounds 2, 3 and 1 (each within the scatter of the next).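

In this assay, the change from 2,3-dichlorophenyl to 2-chlorophenyl gives a 1.6-fold higher number from compound 2 to compound 3 (0.20 log units; within the scatter), so this chloro does not separate the two compounds. The change to 2-chlorophenyl in place of 3-chlorophenyl gives a 1.1-fold lower number from compound 1 to compound 3 (0.05 log units; within the scatter), so the two places shown for a single chloro are not separable either. No evidence is available that bears on this result.

Still open, going by these compounds, is whether a different ring group, such as methoxy or nitrile, or a longer chain to the ring would give a step beyond the scatter.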